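The source may hold more compounds than are shown below. What is called first, only, known or untested is meant among the compounds shown, and "the series" means these compounds.

Of the compounds shown here, three sharing one core have been measured in a functional assay on HeLa cells (Homo sapiens) for cytotoxicity, read by CCK-8 assay, with a stated time of 72 h; on this read-out lower numbers stand for stronger inhibition and higher numbers for weaker inhibition. Compound 1 `C=CCn1c(=O)/c(=C\c2ccccc2Cl)[nH]c(=O)/c1=C\c1ccccc1OC` gives 5100 nM, compound 2 `C=CCn1c(=O)/c(=C\c2cccc(Cl)c2Cl)[nH]c(=O)/c1=C\c1ccccc1OC` gives 1600 nM, and compound 3 `C=CCn1c(=O)/c(=C\c2cccc(Br)c2)[nH]c(=O)/c1=C\c1ccccc1OC` gives 5400 nM, the highest of the three numbers: the step of a 1.1-fold higher number from compound 1 to compound 3 (0.02 log units; within the scatter) stays within the scatter, while the step of a 3.4-fold higher number from compound 2 to compound 3 (0.53 log units; beyond the scatter) lies beyond it. Compound 4 `C=CCn1c(=O)/c(=C\c2cc(F)ccc2C)[nH]c(=O)/c1=C\c1ccccc1OC` differs from compound 3 by 5-fluoro-2-methylphenyl in place of 3-bromophenyl on a double-bonded chain carbon bound to an aromatic carbon. For the measured compounds named here, no measured step repeats this exact exchange. The swap of one halogen-bearing phenyl for another left the number essentially unchanged (a 1.1-fold higher number from compound 1 to compound 3 (0.02 log units; within the scatter)), while adding a second ring substituent lowered it (a 3.2-fold lower number from compound 1 to compound 2 (0.50 log units; beyond the scatter)). Compound 4 likewise carries two ring substituents, so in this assay a small lowering is expected, a 1.5-fold lower number from compound 3 to compound 4 (0.19 log units; within the scatter), giving an estimated 3500 nM with a range from 1200 nM to 10000 nM.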

Compound 4, half-maximal inhibitory concentration: 2900 nM
Estimate against measurement, compound 4: 1.2-fold (0.08 log units) above; the measured number falls inside the stated range.
By their numbers in this assay, from the lowest: compounds 2, 4, 1 and 3 (each within the scatter of the next, the first and the last beyond it).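

In this assay, 5-fluoro-2-methylphenyl brings a methyl and a fluorine to this place, yet compound 4 stays within the scatter of compound 3 (a 1.9-fold lower number from compound 3 to compound 4 (0.27 log units; within the scatter)), compound 2 (a 1.8-fold higher number from compound 2 to compound 4 (0.26 log units; within the scatter)) and compound 1 (a 1.8-fold lower number from compound 1 to compound 4 (0.25 log units; within the scatter)). The place therefore accepts a ring without chlorine or bromine, and compound 4 cannot be separated from compound 2 or compound 3, although those two lie beyond the scatter of each other. Nothing available gives a reason for these numbers. As far as these compounds go, whether a ring carrying an amine or a carboxylic acid here would move the number beyond the scatter stays open.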